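This account rests on a few compounds, and the source may have more. Where it says the series, first, only, none or still open, it means among the compounds named here.

Compound 1 `CCOC(=O)Cn1cnc2c(Cl)ncnc21` is one of two measured members of this series. In a functional assay on G-361 cells (Homo sapiens) for antiproliferative activity, read by colorimetric assay and sulforhodamine B assay, with a stated time of 3 days (a lower number here means a stronger inhibitor, a higher number a weaker inhibitor), compound 1 gives 21400 nM. Compound 2 `CCOC(=O)Cn1cnc2ncnc(Cl)c21` in this assay gives 21400 nM, level with compound 1 at the digits shown and within the scatter. Among the measured compounds shown here, no step between measured compounds is available, so the weight of a halogen swap is not known from these data. Compound 3 `CCOC(=O)Cn1cnc2c(Br)ncnc21` carries bromo in place of chloro on an aromatic carbon. The expected step from compound 1 to compound 3 in this assay is a 1.1-fold lower number from compound 1 to compound 3 (0.03 log units; within the scatter), that is none beyond the scatter. Compound 3 is therefore estimated at 20000 nM, in the range 8000 nM to 50000 nM.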

Compound 3, half-maximal inhibitory concentration: 15800 nM
Compound 3: middle estimate off by 1.3-fold (0.10 log units), on the high side; low and high end bracket the measured number.
By their numbers in this assay, from the lowest: compounds 3, 1 and 2 (each within the scatter of the next).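

In this assay, bromo in place of chloro on this aromatic carbon, next to the ring nitrogen, gives a 1.4-fold lower number from compound 1 to compound 3 (0.13 log units; within the scatter). The first halogen swap read at this position therefore leaves the number within the scatter, so the two halogens cannot be told apart here. No measurement shown accounts for this result.

Still open, from the compounds shown here alone, is whether an amine or a methoxy group on this aromatic carbon would move the number beyond the scatter. Also open, going by these compounds, is whether a carboxylic acid in place of the ethyl ester would do so.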